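From Chloro to Nitro: Estimating Compound 4

This account rests on a few compounds, and the source may have more. Where it says the series, first, only, none or still open, it means among the compounds named here.

Compound 1 `O=C(CCl)Nc1ccc(C(=O)/C=C/c2ccc(Cl)cc2)cc1` gives 8160 nM in a functional assay on SMMC-7721 cells (Homo sapiens) for cytotoxicity, read by MTT assay, with a stated time of 72 h; a higher number here means a weaker inhibitor, a lower number a stronger inhibitor.
Compound 2 `O=C(CCl)Nc1ccc(C(=O)/C=C/c2ccc(F)cc2)cc1` gives 15100 nM in this assay.
Compound 3 `O=C(CSC(=S)N[C@H]1CCOC1=O)Nc1ccc(C(=O)/C=C/c2ccc(Cl)cc2)cc1` gives only a limit of the assay, > 128000 nM, in this assay.

All three compounds share one core, an amide-linked aryl group carrying an unsaturated ketone that ends in a substituted phenyl ring. Compound 3 stands at the upper limit of this assay, where (the limit of > 128000 nM in this assay, at which 1 of the 3 values shown sits); no number is known for it, only that it is at or past the limit. Compound 3 carries a large sulfur-containing side chain, and the change of an at least 15-fold higher number from compound 1 to compound 3 (1.19 log units; beyond the scatter) shows that introducing this side chain weakens inhibition strongly.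

Compound 4 `O=C(CSC(=S)N[C@H]1CCOC1=O)Nc1ccc(C(=O)/C=C/c2ccc([N+](=O)[O-])cc2)cc1` keeps that side chain and alters only the phenyl ring: nitro in place of chloro on an aromatic carbon. The measured step closest to this change is a 1.9-fold higher number from compound 1 to compound 2 (0.27 log units; within the scatter), a swap of one small group for another on the same aromatic carbon, and it made no difference beyond the scatter. Compound 4 is therefore expected to change little from compound 3, and the step that the limit leaves unreadable from compound 3 to compound 4 is estimated to stay within the scatter. Compound 4 is expected near 130000 nM, with a range from 40000 nM to 400000 nM, and most likely only a limit will be reported.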

Compound 4, half-maximal inhibitory concentration: > 128000 nM
Compound 4: only a limit was reported; the forecaster's own chance of this, stated with the estimate: 70%; the middle value does not contradict the limit.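

In this assay, compound 4 gives only a limit, > 128000 nM, not a number. Among the compounds shown here, compound 3 also gives only a limit, so no step between compound 3 and compound 4 can be read. The compounds shown leave open whether nitro in place of chloro changes the result in this assay at all while the large sulfur-containing side chain stays in place.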